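From Chloro to Iodo on the Phenoxy Ring

The source may report more compounds than this note shows. Statements on the series, on what has been measured and on what is new or still open speak of the compounds shown alone.

Compound 1 `Cc1nn(C)c(Oc2cccc(F)c2)c1/C=N\CCCCCCOc1cc2oc(=O)cc(C)c2cc1Cl` and compound 2 `Cc1nn(C)c(Oc2ccc(Cl)cc2)c1/C=N\CCCCCCOc1cc2oc(=O)cc(C)c2cc1Cl` share one core and differ only in the halogenated phenoxy group. In a functional assay on SMMC-7721 cells (Homo sapiens) for antiproliferative activity, read by MTT assay, with a stated time of 72 h (a higher number here means a weaker inhibitor, a lower number a stronger inhibitor), compound 1 gives 23600 nM, and compound 2 gives 2080 nM. For the measured compounds named here, the step of an 11-fold lower number from compound 1 to compound 2 (1.05 log units; beyond the scatter) leaves compound 2 with the lower of the two numbers, with compound 1 as its only neighbour.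

Compound 3 `Cc1nn(C)c(Oc2ccc(I)cc2)c1/C=N\CCCCCCOc1cc2oc(=O)cc(C)c2cc1Cl` is the next step from compound 2: iodo in place of chloro on an aromatic carbon. Going by the values given here, the one measured step bears on it only loosely, since it moved the halogen from one place on the ring to another and changed its identity at the same time, whereas this step keeps the place and exchanges one halogen for another. Among the compounds with values here, no measured pair shows what such an exchange does on this core. The expectation is therefore a step of a 1.4-fold lower number from compound 2 to compound 3 (0.14 log units; within the scatter) in this assay that stays within the scatter, with a slight lean toward a lower number. Compound 3 is estimated at 1500 nM, with a range from 500 nM to 5000 nM.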

Compound 3, half-maximal inhibitory concentration: 13300 nM
Estimate against measurement, compound 3: 8.9-fold (0.95 log units) below; measured number outside the range, above it.
By their numbers in this assay, from the lowest: compound 2; then compounds 3 and 1 (each within the scatter of the next).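

With the place on the ring held fixed, the identity of the halogen proves to matter in this assay: iodo in place of chloro gives a modest but real step (a 6.4-fold higher number from compound 2 to compound 3 (0.81 log units; beyond the scatter)), so the gain seen with compound 2 does not carry over to every halogen at this place. The step to the 4-iodophenyl group from the 3-fluorophenyl group (a 1.8-fold lower number from compound 1 to compound 3 (0.25 log units; within the scatter)) leaves compound 3 level with compound 1, and compound 2 alone stands apart from both others, beyond the scatter. Nothing available explains why chloro and iodo part in this way.

The three compounds leave open whether bromo on this aromatic carbon would track compound 2 or compound 3, and so whether chloro is a narrow optimum or simply one point in a wider series. They also leave open what fluoro, or a group other than a halogen such as an amine or a methoxy group, would do at the same place para to a large group, which would separate the effect of the place from that of the halogen.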